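Working notes: methyl step from compound 2 to compound 3

The source may report more compounds than this note shows. Statements on the series, on what has been measured and on what is new or still open speak of the compounds shown alone.

Measured so far:
compound 1, `Cc1ccc(C2CNN=C2S(=O)(=O)CC2=NCCS2)cc1`, 43.1%
compound 2, `O=S(=O)(CC1=NCCO1)C1=NNCC1c1ccccc1`, "not active" (no number reported)

In a functional assay, read by Griess assay, with a stated time of 150 min, tested at 50 ug/mL (on this read-out lower numbers stand for a weaker effect and higher numbers for a stronger effect at the one concentration tested), compound 1 gives 43.1%. In this assay compound 2 is reported as "not active" (no number reported), so no number stands for compound 2 and its place on the scale is open. Compound 3 `Cc1ccc(C2CNN=C2S(=O)(=O)CC2=NCCO2)cc1` remains to be measured in this assay. (methyl in place of hydrogen on an aromatic carbon). Going by the values given here, no step between measured compounds covers this change, so the size of the step in this assay is unknown; a modest rise is expected, possibly none beyond the scatter. Compound 3 is expected to give about 25%, ranging from 0% to 50%.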

Compound 3, a percentage reported as activity, at one concentration (the size of the read-out at that concentration, not a potency): 45.9%
Compound 3: middle estimate off by 20.9 percentage points, on the low side; the measured number falls inside the stated range.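

In this assay compound 2 is reported as "not active" (no number reported), while compound 3, which carries 4-methylphenyl in place of phenyl, gives 45.9%, so this position separates a compound without a reported number from one with a measurable effect. Exchanging the sulfur of the five-membered ring for oxygen gives a number 2.8 percentage points higher from compound 1 to compound 3 (within the scatter), so the two rings are not told apart when 4-methylphenyl is present. Nothing measured explains the methyl effect. From the compounds shown here alone, whether an ethyl or methoxy group in the same place matches methyl remains open. Going by these compounds, the phenyl compound with the sulfur-containing ring is also open.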